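Benzyl ring substituent survey on a shared core

The source may hold more compounds than are shown below. What is called first, only, known or untested is meant among the compounds shown, and "the series" means these compounds.

Measured in an assay on isolated protein for inhibition of Amine oxidase [flavin-containing] B (Homo sapiens), read by fluorescence and Amplex Red, with stated times of 15 min and 20 min; a higher number here means a weaker inhibitor, a lower number a stronger inhibitor:
compound 1 `C#CCN(CCCCOc1ccc2ccc(=O)oc2c1)Cc1cccc(OC)c1`: 2340 nM
compound 2 `C#CCN(CCCCOc1ccc2ccc(=O)oc2c1)Cc1ccc(C)cc1`: 1680 nM

Among the measured compounds shown here, compound 2 stands at one end of the two numbers, but the only measured step, a 1.4-fold lower number from compound 1 to compound 2 (0.14 log units; within the scatter), is within the scatter, so compounds 1 and 2 are not separable on these data. Compound 3 `C#CCN(CCCCOc1ccc2ccc(=O)oc2c1)Cc1ccccc1` differs from compound 2 by hydrogen in place of methyl on an aromatic carbon of the six-membered aromatic ring of carbon only, para to a large group. For the measured compounds named here, the one step available on this ring, from compound 1 to compound 2, exchanged one substituent for another without a change beyond the scatter; no measured step removes a substituent from this ring altogether. The step into compound 3 is therefore expected to be small, if anything toward a slightly higher number. Compound 3 is expected at about 2200 nM, between 900 nM and 5500 nM. The expected step is a 1.3-fold higher number from compound 2 to compound 3 (0.12 log units; within the scatter), within the scatter.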

Compound 3, half-maximal inhibitory concentration: 978 nM
The estimate for compound 3 lay 2.2-fold (0.35 log units) above the measured number; low and high end bracket the measured number.
By their numbers in this assay, from the lowest: compounds 3, 2 and 1 (each within the scatter of the next, the first and the last beyond it).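

In this assay, hydrogen in place of methyl on an aromatic carbon gives a 1.7-fold lower number from compound 2 to compound 3 (0.23 log units; within the scatter), so the 4-methylphenyl and phenyl compounds cannot be told apart. Hydrogen in place of methoxy on an aromatic carbon gives a 2.4-fold lower number from compound 1 to compound 3 (0.38 log units; beyond the scatter), a modest change and the first step on this ring to lie beyond the scatter, showing that the unsubstituted benzyl compound can be separated from compound 1 even though compound 2 can be separated from neither. No supporting data bear on why these steps take this size.

Open, from the compounds shown here alone, is whether a fluorine, a chlorine or a nitrile on this ring would keep the number of compound 3 or move it. Also open, going by these compounds, is how a shorter chain in place of the present one would act on the benzyl compound.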